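The source may report more compounds than this note shows. Statements on the series, on what has been measured and on what is new or still open speak of the compounds shown alone.

Measured in an ADME assay on MDCK cells (Canis lupus familiaris) for cytotoxicity; a lower number here means that less compound is tolerated, a higher number that more compound is tolerated:
Compound 1 `O=[N+]([O-])C1=NNc2ncnn2C1c1ccc(O)c(O)c1`: > 1630000 nM (a limit, not a number)
Compound 2 `O=[N+]([O-])C1=CNc2ncnn2C1O`: 123000 nM

Compound 1 stands at the top of the pair, as the limit of > 1630000 nM in this assay, at which 1 of the 2 values shown sits, shows. Compound 3 `CSc1nc2n(n1)C(c1ccc(O)c(O)c1)C([N+](=O)[O-])=NN2` has methylsulfanyl in place of hydrogen on an aromatic carbon of the core of compound 1 (methylsulfanyl in place of hydrogen on an aromatic carbon). Within the data shown here, no measured step in this assay covers this change, so the expectation is only loosely anchored. The expected step, an at least 1.6-fold lower number from compound 1 to compound 3 (0.21 log units; that floor lies within the scatter), is modest and downward, and may not exceed the scatter. The estimate for compound 3 is 1000000 nM, with an expected range of 300000 nM to 2000000 nM.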

Compound 3, half-maximal cytotoxic concentration: 362000 nM
Compound 3: the middle estimate sits 2.8-fold (0.44 log units) above what was measured; measured number inside the range.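

In this assay, among these compounds, methylsulfanyl in place of hydrogen on an aromatic carbon gives the only step that can be read: an at least 4.5-fold lower number from compound 1 to compound 3 (0.65 log units; beyond the scatter). This position, on the five-membered aromatic ring with 3 nitrogen, therefore responds to substitution, with a change beyond the scatter. The step remains a floor because compound 1 stands at a limit: the limit of > 1630000 nM in this assay, at which 1 of the 3 values shown sits. As far as these compounds go, whether an amine or a longer chain on this carbon moves the number as far remains open. So does whether methylsulfanyl has the same effect on compound 2.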